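The source may report more compounds than this note shows. Statements on the series, on what has been measured and on what is new or still open speak of the compounds shown alone.

Measured compounds and values in a functional assay (blood) for inhibition, with Homo sapiens as the target; on this read-out higher numbers stand for weaker inhibition and lower numbers for stronger inhibition:
- compound 1, `CO/N=C(\C)c1ccc(Sc2cc(F)cc(C3CCOCC3)c2)cc1`, gives 110 nM
- compound 2, `C/C(=N\OCCF)c1ccc(Sc2cc(F)cc(C3CCOCC3)c2)cc1`, gives 40 nM
- compound 3, `C/C(=N\OCc1ccncc1)c1ccc(Sc2cc(F)cc(C3CCOCC3)c2)cc1`, gives 300 nM

Compound 2 has the lowest number of the three in this assay; compound 1 is nearest, and compound 3 furthest. Among the compounds with values here, the steps so far all change the substituent on the saturated chain carbon bound to an oxygen: a 2.8-fold lower number from compound 1 to compound 2 (0.44 log units; beyond the scatter), a 2.7-fold higher number from compound 1 to compound 3 (0.44 log units; beyond the scatter) and a 7.5-fold higher number from compound 2 to compound 3 (0.88 log units; beyond the scatter). Both substitutions away from hydrogen on that carbon moved the number beyond the scatter, in opposite directions, with the larger pyridin-4-yl group going the weaker way.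

Compound 4, `CCOC(=O)/C(=N\O)c1ccc(Sc2cc(F)cc(C3CCOCC3)c2)cc1`, is not yet measured. Relative to compound 2 the change is a group of 8 heavy atoms (4 carbon, 1 nitrogen, 3 oxygen; no ring) in place of a group of 7 heavy atoms (4 carbon, 1 nitrogen, 1 oxygen, 1 fluorine; no ring), on an aromatic carbon. Within the data shown here, this is a larger rewrite of the side chain than any measured step: the group that leaves and the group that enters differ in every part, so no measured step matches it directly. Among the measured compounds shown here, the measured steps show only that this carbon is sensitive to substitution, and compound 1, the one measured compound with hydrogen at that carbon, gives 110 nM. An expected step of a 3.8-fold higher number from compound 2 to compound 4 (0.57 log units; beyond the scatter) in this assay is therefore weakly supported, with wide uncertainty. Compound 4 is expected at 150 nM, within 45 nM to 500 nM.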

Compound 4, half-maximal inhibitory concentration: 170 nM
The estimate for compound 4 lay 1.1-fold (0.05 log units) below the measured number; measured number inside the range.
By their numbers in this assay, from the lowest: compound 2; then compounds 1, 4 and 3 (each within the scatter of the next, the first and the last beyond it).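

In this assay, the side chain on the aromatic carbon para to a large group accepts a very different group, one with 1 hydrogen-bond donor and 2 double bonds outside aromatic rings: this change gives a 1.5-fold higher number from compound 1 to compound 4 (0.19 log units; within the scatter). Within the data shown here, this position therefore does not respond to every rewrite of the side chain with a clear shift, which the earlier steps, all beyond the scatter, did not show. Against the fluorinated side chain, the same group gives a 4.3-fold higher number from compound 2 to compound 4 (0.63 log units; beyond the scatter), so compound 2 remains apart from both compound 1 and compound 4, and no measurement at hand explains either step.

Compound 4 changes the ether on the oxime oxygen and the group on the oxime carbon together, so the compounds shown leave open what the free oxime hydroxyl and the ethyl ester each contribute. Also open, on these data alone, is how a carboxylic acid or a primary amide in place of the ethyl ester would read in this assay, and whether a longer fluoroalkyl chain on the oxime oxygen would extend the result of compound 2.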